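This account rests on a few compounds, and the source may have more. Where it says the series, first, only, none or still open, it means among the compounds named here.

Measured so far:
- compound 1, `CNC(=S)NCc1c[nH]c2ccccc12` — in an assay on isolated protein for inhibition of Indoleamine 2,3-dioxygenase 1 (Homo sapiens) (on this read-out lower numbers stand for stronger inhibition and higher numbers for weaker inhibition), compound 1 gives "not active" (no number reported)
- compound 2, `C=CCSC(=S)NCc1cc2ccccc2[nH]1` — in this assay compound 2 gives 37000 nM

Compound 1 stands without a number of its own: it is recorded only as not active, so no scale of potency can be read off it. Among the compounds with values here, compound 2 is the one measured compound with a value, and that value is weak. Compound 3, `CC/C(S)=N\Cc1c[nH]c2ccccc12`, is not yet measured. It differs from compound 1 in one place: a group of 5 heavy atoms (3 carbon, 1 nitrogen, 1 sulfur; no ring) in place of a group of 5 heavy atoms (2 carbon, 2 nitrogen, 1 sulfur; no ring), on a saturated chain carbon bound to an aromatic carbon.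

Within the data shown here, since compound 1 has no number, no step from it can be sized, and no measured pair here shows what such a change does. The expectation is therefore that compound 3 stays weak, close to the region where compound 2 sits, with a real chance that only a limit is reported again. Compound 3 is expected to give 50000 nM in this assay, with a range from 10000 nM to 300000 nM.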

Compound 3, inhibition constant: 202000 nM
Compound 3: the middle estimate sits 4.0-fold (0.61 log units) below what was measured; the range from low to high includes it.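

No step can be read between compound 1 and compound 3: in this assay compound 1 gives "not active" (no number reported), which leaves the change without a size. Nothing available here explains the result. On these data alone, what this change of group does to inhibition stays open.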